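Aryl-amide variation and cytotoxicity across the piperazine series

The compounds below may be only part of what the source reports. "The series", "measured", "known", "first", "only" and "open" are said of these compounds alone.

Compound 2 `Cc1ccc(C(=O)N2CCN(CC(=O)N3CCN(CCCc4c[nH]c5ccccc45)CC3)CC2)cc1` stands second highest of three numbers in an ADME assay on HEK293 cells (Homo sapiens) for cytotoxicity, read by MTT assay, with a stated time of 72 h (on this read-out higher numbers stand for weaker inhibition and lower numbers for stronger inhibition), where compound 2 gives 159000 nM. Compound 1 `O=C(CN1CCN(C(=O)c2ccc(Cl)cc2)CC1)N1CCN(CCCc2c[nH]c3ccccc23)CC1` gives 98200 nM and compound 3 `O=C(CN1CCN(C(=O)c2cccc(F)c2)CC1)N1CCN(CCCc2c[nH]c3ccccc23)CC1` gives 182000 nM; both neighbours lie within the scatter of compound 2. Compound 4 `O=C(CN1CCN(C(=O)c2ccccc2F)CC1)N1CCN(CCCc2c[nH]c3ccccc23)CC1` carries 2-fluorophenyl in place of 4-methylphenyl on a carbonyl carbon. The two steps that bear on this change are a 1.6-fold higher number from compound 1 to compound 2 (0.21 log units; within the scatter) and a 1.1-fold higher number from compound 2 to compound 3 (0.06 log units; within the scatter); the step of a 1.9-fold higher number from compound 1 to compound 3 (0.27 log units; within the scatter) also stays within the scatter. Since a fluorophenyl has already replaced a methylphenyl without a step beyond the scatter, no change beyond the scatter is expected for this assay in either direction, so the step of a 1.1-fold lower number from compound 2 to compound 4 (0.03 log units; within the scatter) is estimated. Compound 4 is expected to give 150000 nM, estimated between 70000 nM and 320000 nM.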

Compound 4, half-maximal inhibitory concentration: 133000 nM
For compound 4 the middle estimate is 1.1-fold (0.05 log units) above the measured one, and the stated range covers the measured number.
By their numbers in this assay, from the lowest: compounds 1, 4, 2 and 3 (each within the scatter of the next).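

In this assay, 2-fluorophenyl on this carbonyl carbon does not separate from 4-methylphenyl, with a 1.2-fold lower number from compound 2 to compound 4 (0.08 log units; within the scatter), or from its isomer 3-fluorophenyl, with a 1.4-fold lower number from compound 3 to compound 4 (0.14 log units; within the scatter). The step from 4-chlorophenyl, a 1.4-fold higher number from compound 1 to compound 4 (0.13 log units; within the scatter), also stays within the scatter, so all four aryl groups shown now lie within the scatter of one another at this position. No supporting measurement bears on this result. The compounds shown leave open whether an aryl group carrying an amine or a carboxylic acid would give a step beyond the scatter. They also leave open whether a cyclohexyl group in place of the aryl ring would do so.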